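The source may hold more compounds than are shown below. What is called first, only, known or untested is meant among the compounds shown, and "the series" means these compounds.

The study groups three measured compounds and one still to be measured. Compound 1 `COc1ccc(/C=C2\Oc3cc(OC)c(OC)c(OC)c3C2=O)cc1O` and compound 2 `COc1ccc(/C=C2\Oc3cc(OC)c(OC)c(OC)c3C2=O)cc1F` share one core; compound 3 `COc1ccc(-c2cc(=O)c3cc(OC)c(OC)c(OC)c3o2)cc1` and compound 4 `COc1ccc(-c2cc(=O)c3cc(OC)c(OC)c(OC)c3o2)cc1O` share another. In a functional assay on K562 cells (Homo sapiens) for inhibition, read by MTT assay, with a stated time of 5 days (a lower number here means a stronger inhibitor, a higher number a weaker inhibitor), compound 1 gives 18000 nM. For compound 2 this assay reports only a limit, > 50000 nM. For the measured compounds named here, the one measured step, fluoro in place of hydroxy on an aromatic carbon, gives an at least 2.7-fold higher number from compound 1 to compound 2 (0.44 log units; beyond the scatter), which rests on (the limit of > 50000 nM in this assay, at which 1 of the 3 values shown sits). In this assay compound 3 gives 830 nM, the lowest of the two numbers shown; compound 1 sits a long way above it. The remaining value, that of compound 2, is a limit.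

Compound 4 differs from compound 3 by hydroxy in place of hydrogen on an aromatic carbon. Going by the values given here, no measured step matches this change: the step from compound 1 to compound 2 exchanges hydroxy for fluoro, not hydrogen, and sits on a different core. Among the compounds with values here, what the numbers show is that a hydroxy-bearing compound, compound 1, is the one of its pair that yields a number at all. The expectation is therefore a step of a 1.1-fold higher number from compound 3 to compound 4 (0.04 log units; within the scatter), that is, no clear change beyond the scatter in this assay. Compound 4 is estimated at 900 nM, within a range from 300 nM to 4000 nM.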

Compound 4, half-maximal inhibitory concentration: 40 nM
The estimate for compound 4 lay 23-fold (1.35 log units) above the measured number; measured number below the stated range.
By their numbers in this assay, from the lowest: compound 4; then compound 3; then compound 1. At a limit, above all of these: compound 2.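

The hydroxy on the aromatic carbon ortho to a methoxy group proves decisive in this assay on the core of compound 3, where replacing hydrogen with it gives a 21-fold lower number from compound 3 to compound 4 (1.32 log units; beyond the scatter) as a large step beyond the scatter. For the compounds shown here, this is the first direct reading of hydroxy against hydrogen at this position, since the earlier step on the other core set fluoro against hydroxy and so could say nothing about what hydroxy does compared with hydrogen. The compounds shown offer no measurement that accounts for why a change of one heavy atom has a step of this size.

On these data alone, what an amine or an ethoxy group would do at this same position on the core of compound 3 stays open, so it cannot be said whether the large step belongs to hydroxy alone or would also appear with another group there. Also open is whether the change from hydrogen to hydroxy would give a similar step on the core of compound 1, for which the compounds shown offer no such pair.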